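A few compounds are considered here, and "the series" means these few. Any claim that something is new, unique, unknown or untested is made for them only; others in the source may bear on it.

Measured in an assay on isolated protein for inhibition of Apoptosis regulator Bcl-2 (Homo sapiens), read by fluorescence polarization, with stated times of 5 min and 10 min; a higher number here means a weaker inhibitor, a lower number a stronger inhibitor:
- compound 1 `CC(C)=CCCC1=CC[C@@H](C(=O)Nc2ccc(C(=O)O)cc2)[C@H](c2ccccc2)C1`: 2200 nM
- compound 2 `CC(C)=CCCC1=CC[C@@H](C(=O)NCCC(=O)O)[C@H](c2ccccc2)C1`: a limit only, > 23000 nM
- compound 3 `CC(C)=CCCC1=CC[C@H](C(=O)Nc2ccc(C(=O)O)cc2)[C@@H](c2ccccc2)C1`: a limit only, > 23000 nM

For the measured compounds named here, compound 1 is the only member with a number in this assay. The change 2-carboxyethyl in place of 4-carboxyphenyl on an amide-type nitrogen gave an at least 10-fold higher number from compound 1 to compound 2 (1.01 log units; beyond the scatter). The two cores differ as the two compounds have the same atoms and bonds and differ only in configuration as drawn: 2 of 2 stereo elements differ (all stereocentres are inverted: mirror images); a stereocentre at a saturated ring carbon is drawn R in compound 1 and S in compound 3; a stereocentre at a saturated ring carbon is drawn R in compound 1 and S in compound 3, giving an at least 10-fold higher number from compound 1 to compound 3 (1.01 log units; beyond the scatter); both steps are bounded by the limit of > 23000 nM in this assay, at which 2 of the 3 values shown sit, and the second rests on (the fact that compounds 1 and 3 differ only in the configuration as drawn).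

Compound 4 `CC(C)=CCCC1=CC[C@H](C(=O)NCCC(=O)O)[C@@H](c2ccccc2)C1` is not yet measured. It carries the same kind of change as compound 2, (2-carboxyethyl in place of 4-carboxyphenyl on an amide-type nitrogen), at the same place, on the core of compound 3. For compound 4 the step is expected to be a step that the limit leaves unreadable from compound 3 to compound 4, because an at least 10-fold higher number from compound 1 to compound 2 (1.01 log units; beyond the scatter) was seen for the same change. Compound 4 is therefore estimated at 60000 nM, most likely reported as a limit again.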

Compound 4, inhibition constant: > 23000 nM
Compound 4 was reported as a limit; the forecaster's own chance of this, stated with the estimate: 95%; the middle value does not contradict the limit.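

In this assay compound 4 gives > 23000 nM, which is a limit. No step can be read from compound 2 or compound 3 to compound 4, since all three values are limits. The compounds shown leave open how the 2-carboxyethyl change acts on the core of compound 3.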